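Replacing a urea with a simple benzamide on a shared core

A few compounds are considered here, and "the series" means these few. Any claim that something is new, unique, unknown or untested is made for them only; others in the source may bear on it.

Three compounds share a core and are tested in a functional assay on SF-539 cells (Homo sapiens) for inhibition, read by sulforhodamine B assay, with a stated time of 48 h; a higher number here means that more compound is tolerated, a lower number that less compound is tolerated. Compound 1, with the structure `O=C(Nc1cccc(-n2cc(-c3ccncc3)c(-c3ccc(Cl)c(O)c3)n2)c1)Nc1ccc(Cl)c(Cl)c1`, gives only a limit of the assay, > 32500 nM; this is a limit, not a number, as the limit of > 32500 nM in this assay, at which 1 of the 3 values shown sits, states. Compound 2, with the structure `O=C(Nc1cccc(-n2cc(-c3ccncc3)c(-c3ccc(Cl)c(O)c3)n2)c1)Nc1cc(C(F)(F)F)cc(C(F)(F)F)c1`, gives 2890 nM. Compound 3, with the structure `COc1cc(-c2nn(-c3cccc(NC(=O)Nc4cccc(C(F)(F)F)c4)c3)cc2-c2ccncc2)ccc1Cl`, gives 21000 nM, the highest of the two numbers that are available, and its nearest neighbour is compound 2 with a number that lies well beyond the usual scatter of the measurement.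

The step to be followed leads from compound 3 to compound 4, with the structure `COc1cc(-c2nn(-c3cccc(NC(=O)c4ccccc4)c3)cc2-c2ccncc2)ccc1Cl`. The change is phenyl in place of (3-(trifluoromethyl)phenyl)amino on a carbonyl carbon. Within the data shown here, no step between two measured compounds separates only these two groups, so nothing already measured tells how large this change should be. With compound 3 already at 21000 nM, the expectation for compound 4 is a number near that of compound 3 or somewhat higher, a step of a 1.4-fold higher number from compound 3 to compound 4 (0.15 log units; within the scatter). Compound 4 is therefore estimated at 30000 nM, with a range from 8000 nM to 100000 nM.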

Compound 4, concentration lethal to 50% of the cells: > 100000 nM
Compound 4 was reported as a limit; the forecaster's own chance of this, stated with the estimate: 40%; middle value at least 3.3-fold (0.52 log units) away from the limit.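

In this assay, phenyl in place of (3-(trifluoromethyl)phenyl)amino on the carbonyl carbon gives an at least 4.7-fold higher number from compound 3 to compound 4 (0.67 log units; beyond the scatter). Among these compounds, this is the first direct view of this position, and it shows that the group on the carbonyl carbon makes a difference beyond the scatter in how much compound the cells tolerate. The full size of the step remains unknown, because compound 4 gives a limit rather than a number: the limit of > 100000 nM in this assay, at which 1 of the 4 values shown sits.

The change removes the amino nitrogen and the trifluoromethyl group together, and the compounds shown do not separate the two. A plain phenylamino group or a phenyl ring carrying trifluoromethyl on the same carbonyl carbon would be needed to tell which part of the change matters.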